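A few compounds are considered here, and "the series" means these few. Any claim that something is new, unique, unknown or untested is made for them only; others in the source may bear on it.

In a functional assay on MCF7 cells (Homo sapiens) for antiproliferative activity, read by MTT assay (a higher number here means a weaker inhibitor, a lower number a stronger inhibitor), compound 1 `COc1cc2c(Oc3ccc(NC(=O)Nc4ccc(C(F)(F)F)cc4Cl)cc3)ccnc2cc1OCCCCCCC(=O)NO` gives 500 nM and compound 2 `COc1cc2c(Oc3ccc(NC(=O)Nc4ccccc4F)cc3)ccnc2cc1OCCCCCCC(=O)NO` gives 660 nM. The change between these two is a 1.3-fold higher number from compound 1 to compound 2 (0.12 log units; within the scatter). Compound 3 `COc1cc2c(Oc3ccc(NC(=O)Nc4ccc(Cl)c(C(F)(F)F)c4)cc3)ccnc2cc1OCCCCCCC(=O)NO` gives 5150 nM, the highest of the three numbers, which makes it the weakest inhibitor measured so far in this assay.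

Compound 4 `COc1cc2c(Oc3ccc(NC(=O)Nc4ccc(C)cc4C)cc3)ccnc2cc1OCCCCCCC(=O)NO` keeps the shared core and alters one group on an amide-type nitrogen, with 2,4-dimethylphenyl in place of 4-chloro-3-(trifluoromethyl)phenyl on an amide-type nitrogen. Within the data shown here, no measured compound carries this new group, so the forecast rests on analogy. The name 2,4-dimethylphenyl shares its leading 2 with 2-chloro-4-(trifluoromethyl)phenyl in compound 1 and 2-fluorophenyl in compound 2, while the group in compound 3 lacks it. Among the measured compounds shown here, the steps that bear on this are a 10-fold higher number from compound 1 to compound 3 (1.01 log units; beyond the scatter) and a 7.8-fold higher number from compound 2 to compound 3 (0.89 log units; beyond the scatter), both read here in reverse. For the measured compounds named here, no compound goes against this trend, but three compounds are thin support, and neither methyl-bearing comparison exists. A step of similar or somewhat smaller size towards a lower number therefore seems likely. The expected change is a 6.4-fold lower number from compound 3 to compound 4 (0.81 log units; beyond the scatter). For compound 4, the estimated value is 800 nM, with an expected range from 250 nM to 3000 nM.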

Compound 4, half-maximal inhibitory concentration: 3430 nM
Compound 4: the middle estimate sits 4.3-fold (0.63 log units) below what was measured; measured number above the stated range.
By their numbers in this assay, from the lowest: compounds 1 and 2 (each within the scatter of the next); then compounds 4 and 3 (each within the scatter of the next).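

In this assay, the 2,4-dimethylphenyl group on the amide-type nitrogen does not separate compound 4 from compound 3, with a 1.5-fold lower number from compound 3 to compound 4 (0.18 log units; within the scatter), so a leading 2 in the group's name is not enough on its own to go with a lower number. Compound 4 instead stands apart from the two compounds whose groups carry chloro or fluoro at that leading 2, with a 5.2-fold higher number from compound 2 to compound 4 (0.72 log units; beyond the scatter) and a 6.9-fold higher number from compound 1 to compound 4 (0.84 log units; beyond the scatter). Across these four compounds, the lower numbers therefore go with the 2-chloro and 2-fluoro names, and compound 4 is the exception to the simpler link between a leading 2 and a lower number that the first three compounds suggested.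

A 2-methylphenyl group, with its single methyl, would help show whether the methyl named at 2 or the one named at 4 ties compound 4 to compound 3. No measurement at hand explains why the dimethyl group and the groups of compound 1 and compound 2 part in this way.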